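From pyridin-4-yl to 1-methyl-1H-pyrazol-5-yl on compound 1

This account rests on a few compounds, and the source may have more. Where it says the series, first, only, none or still open, it means among the compounds named here.

Compound 1 `CCN(c1ccc(C#N)c(Cl)c1)c1cc(-c2ccncc2)ccc1C`: 2900 nM
Compound 2 `Cn1nccc1-c1cccc2c1CCCN2c1ccc(C#N)c(C(F)(F)F)c1`: > 30000 nM (a limit)

For the measured compounds named here, in a functional assay on VCaP cells (Homo sapiens) for antiproliferative activity, read by CCK-8 assay, with a stated time of 6 days (a higher number here means a weaker inhibitor, a lower number a stronger inhibitor), compound 1 gives 2900 nM as the only true number so far. Compound 2 gives > 30000 nM as its result, which is a limit of the assay. Compound 3 `CCN(c1ccc(C#N)c(Cl)c1)c1cc(-c2ccnn2C)ccc1C` carries 1-methyl-1H-pyrazol-5-yl in place of pyridin-4-yl on an aromatic carbon and otherwise keeps the core of compound 1. Going by the values given here, no measured step covers this swap, so a modest weakening in this assay is expected, perhaps none beyond the scatter. The expected change is a 1.4-fold higher number from compound 1 to compound 3 (0.14 log units; within the scatter) as an estimate. Compound 3 is estimated at 4000 nM with an expected range from 1000 nM to 20000 nM for the measurement.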

Compound 3, half-maximal inhibitory concentration: 1670 nM
For compound 3 the middle estimate is 2.4-fold (0.38 log units) above the measured one; the measured number falls inside the stated range.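

In this assay, replacing pyridin-4-yl with 1-methyl-1H-pyrazol-5-yl on this aromatic carbon, para to a methyl group, gives a 1.7-fold lower number from compound 1 to compound 3 (0.24 log units; within the scatter). The two rings therefore cannot be told apart here, although one is six-membered with one hetero atom and the other five-membered with two. Nothing measured here accounts for this result.

As far as these compounds go, whether the same carbon would also accept an amine, a carboxylic acid or a longer alkyl chain stays open. So does whether the same swap would give a similar result on a different core.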